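The compounds below may be only part of what the source reports. "The series", "measured", "known", "first", "only" and "open" are said of these compounds alone.

In an ADME assay on C8166 cells (Homo sapiens) for cytotoxicity, read by MTT assay (on this read-out lower numbers stand for higher toxicity in this test and higher numbers for lower toxicity in this test), compound 1 `Cc1ccc(-n2cc(C(=O)O)c(=O)c3c(O)c(Cc4cccc(Cl)c4F)ccc32)cc1C` gives 316000 nM as the higher of the two numbers at hand, and the gap to compound 2 `O=C(O)c1cn(Cc2ccccc2)c2ccc(Cc3ccccc3F)c(O)c2c1=O` at 156000 nM lies beyond the scatter. Compound 3 `O=C(O)c1cn(Cc2ccc(F)c(F)c2)c2ccc(Cc3cccc(Cl)c3F)c(O)c2c1=O` is still unmeasured and differs from compound 1 by 3,4-difluorobenzyl in place of 3,4-dimethylphenyl on an aromatic nitrogen. Among the measured compounds shown here, no measured pair shows this change alone, but compound 2 also carries a benzyl group on an aromatic nitrogen and gives 156000 nM here. A small downward step in this assay is therefore expected, estimated as a 1.9-fold lower number from compound 1 to compound 3 (0.27 log units; within the scatter) overall. For compound 3 the estimated value is 170000 nM with an expected range of 70000 nM to 400000 nM around it.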

Compound 3, half-maximal cytotoxic concentration: 71400 nM
Compound 3: the middle estimate sits 2.4-fold (0.38 log units) above what was measured; low and high end bracket the measured number.
By their numbers in this assay, from the lowest: compound 3; then compound 2; then compound 1.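

In this assay, 3,4-difluorobenzyl in place of 3,4-dimethylphenyl on the aromatic nitrogen gives a 4.4-fold lower number from compound 1 to compound 3 (0.65 log units; beyond the scatter) and so shows that this position alone can move the read-out beyond the scatter, towards higher toxicity in this test. The change alters both the ring's substituents and the link to the nitrogen, and this single step cannot separate the two. Nothing at hand explains the step. Going by these compounds, whether 3,4-dimethylbenzyl or 3,4-difluorophenyl would separate these two parts stays open. On these data alone, how an amine on that ring would read also stays open.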